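One Hydroxy Change Tried on a Second Core

A few compounds are considered here, and "the series" means these few. Any claim that something is new, unique, unknown or untested is made for them only; others in the source may bear on it.

The measured compounds:
Compound 1 `COc1cc2c(/C=C3/C(=O)N(C)c4ccccc43)c(Cl)n(C)c2cc1C` gives 330 nM in a functional assay on cells (Cancer cell lines, Homo sapiens) for inhibition, with a stated time of 48 h; a higher number here means a weaker inhibitor of growth, a lower number a stronger inhibitor of growth.
Compound 2 `COc1cc2c(/C=C3/C(=O)N(C)c4ccc(O)cc43)c(Cl)n(C)c2cc1C` gives 110 nM in this assay.
Compound 3 `COc1cc2c(/C=C3/C(=O)N(C)c4ccccc43)c[nH]c2cc1C` gives 4170 nM in this assay.

Compound 2 differs from compound 1 by hydroxy in place of hydrogen on an aromatic carbon, and that change produced a 3.0-fold lower number from compound 1 to compound 2 (0.48 log units; beyond the scatter). Compound 3 carries a different core; the difference between the two cores is not broken down here. In this assay compound 3 gives the highest number of the three.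

Compound 4 `COc1cc2c(/C=C3/C(=O)N(C)c4ccc(O)cc43)c[nH]c2cc1C` has not been measured. It differs from compound 3 by hydroxy in place of hydrogen on an aromatic carbon, the same change as that from compound 1 to compound 2. Because a 3.0-fold lower number from compound 1 to compound 2 (0.48 log units; beyond the scatter) was modest, a similar step is expected here, roughly a 3.0-fold lower number from compound 3 to compound 4 (0.47 log units; beyond the scatter). Compound 4 is therefore estimated to give about 1400 nM in this assay, most likely between 600 nM and 3500 nM.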

Compound 4, concentration for 50% growth inhibition: 5890 nM
Compound 4: middle estimate off by 4.2-fold (0.62 log units), on the low side; the whole stated range lies below it.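

On the core of compound 3, the hydroxy change gave a 1.4-fold higher number from compound 3 to compound 4 (0.15 log units; within the scatter) in this assay, so it brought no clear change there. The clear effect seen on the core of compound 1 therefore did not carry over to this second core, and the two steps differ: the same change on two cores in this assay, a 3.0-fold lower number (0.48 log units; beyond the scatter) from compound 1 to compound 2 and a 1.4-fold higher number (0.15 log units; within the scatter) from compound 3 to compound 4, 4.2-fold (0.63 log units) apart, beyond the scatter of two such steps. This shows that the step cannot be assumed to transfer between these two cores, but a single pair on each core does not show which difference between the cores matters or how the change would behave on any further core.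

On these data alone, it remains open whether an amine or a carboxylic acid in the same place would also act differently on the two cores.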